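Iodo in Place of Trifluoromethyl on the Aromatic Carbon

The source may hold more compounds than are shown below. What is called first, only, known or untested is meant among the compounds shown, and "the series" means these compounds.

Three compounds have numbers in an ADME assay on the whole organism with Oryza sativa as the target, tested at 10 uM; a higher number here means a weaker effect of the compound at the concentration tested, a lower number a stronger effect. Compound 1 `CCCCCc1ccc(NC(=O)N[C@@H](C)c2ccccc2)cc1` gives 93%, compound 2 `CCCCCCc1ccc(NC(=O)N[C@@H](C)c2ccccc2)cc1` gives 99%, and compound 3 `C[C@H](NC(=O)Nc1ccc(C(F)(F)F)cc1)c1ccccc1` gives 94%. Compound 3 stands second highest of the three, nearest compound 1 and furthest from compound 2, both gaps within the scatter. Compound 4 `C[C@H](NC(=O)Nc1ccc(I)cc1)c1ccccc1` differs from compound 3 by iodo in place of trifluoromethyl on an aromatic carbon. Going by the values given here, the steps that bear on this change also exchange the group on that aromatic carbon: a number 1 percentage points higher from compound 1 to compound 3 (within the scatter) and a number 5 percentage points lower from compound 2 to compound 3 (within the scatter), each within the scatter. Because compound 3 gives 94% and those two steps stayed within the scatter, compound 4 is expected to show a step of no change at the digits printed from compound 3 to compound 4 (within the scatter), none beyond the scatter. Compound 4 is therefore estimated at 94%, within 85% to 100%.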

Compound 4, a percentage reported as activity, at one concentration (the size of the read-out at that concentration, not a potency): 95%
Compound 4: middle estimate off by 1 percentage points, on the low side, and the stated range covers the measured number.
By their numbers in this assay, from the lowest: compounds 1, 3, 4 and 2 (each within the scatter of the next).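

Iodo, a single heavy atom, now joins the groups on this aromatic carbon in this assay, with the steps reading a number 1 percentage points higher from compound 3 to compound 4 (within the scatter) and a number 2 percentage points higher from compound 1 to compound 4 (within the scatter) and a number 4 percentage points lower from compound 2 to compound 4 (within the scatter) as its comparisons. So far, then, neither the replacement of trifluoromethyl by one iodine atom nor the exchange of either alkyl chain for iodo has moved a compound beyond the scatter. No evidence on this result is at hand. Going by these compounds, whether an amine or a carboxylic acid on this carbon would stand apart from these compounds remains open.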